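Amide series notes: from compound 3 to compound 4

This account rests on a few compounds, and the source may have more. Where it says the series, first, only, none or still open, it means among the compounds named here.

In an assay on HEK293 cells for agonist activity at transient receptor potential cation channel subfamily M member 8 (Homo sapiens), read by fluorescence and calcium flux, with a stated time of 15 min (on this read-out lower numbers stand for an effect already at smaller amounts and higher numbers for an effect only at larger amounts of compound), the three measured compounds give:
compound 1 `CCN(Cc1cccs1)C(=O)C(C)Oc1ccc(C)cc1`: 889 nM
compound 2 `CCN(Cc1cccs1)C(=O)c1cc2cc(C)ccc2o1`: 120 nM
compound 3 `Cc1ccc(OCC(=O)N(Cc2cccs2)c2ccnn2C)cc1`: 422 nM

Compound 3 holds the second highest number of the three. Compound 1 stands at a higher number, beyond the scatter, and compound 2 at a lower number, also beyond the scatter. Compound 4 `Cc1ccc(OCC(=O)N(Cc2cccs2)c2c(C)n[nH]c2C)cc1` differs from compound 3 by 3,5-dimethyl-1H-pyrazol-4-yl in place of 1-methyl-1H-pyrazol-5-yl on an amide-type nitrogen. Within the data shown here, no pair of measured compounds differs in a single place, so the weight of this change is untested here. The step of a 1.4-fold higher number from compound 3 to compound 4 (0.15 log units; within the scatter) is expected to be small, toward a somewhat higher number, close to the scatter. Compound 4 is estimated at 600 nM, with a range from 200 nM to 2000 nM.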

Compound 4, half-maximal effective concentration: 0.3 nM
Compound 4: middle estimate off by 2000-fold (3.30 log units), on the high side; the measured number lies below the stated range.
By their numbers in this assay, from the lowest: compound 4; then compound 2; then compound 3; then compound 1.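

In this assay, among these compounds, the group on the amide-type nitrogen turns out to be a highly sensitive position: 3,5-dimethyl-1H-pyrazol-4-yl in place of 1-methyl-1H-pyrazol-5-yl gives a 1400-fold lower number from compound 3 to compound 4 (3.15 log units; beyond the scatter) as the first step in these notes that changes one place. The entering group carries a hydrogen-bond donor that the leaving group lacks, but no measurement on hand accounts for the size of the step. As far as these compounds go, the exchange alters several features at once, so it remains open which of them carries the step. Also open, from the compounds shown here alone, is whether an amino or carboxylic acid group on this ring would keep so low a number.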